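Swapping a thiazole for a thiadiazole on a shared amine

A few compounds are considered here, and "the series" means these few. Any claim that something is new, unique, unknown or untested is made for them only; others in the source may bear on it.

Of the compounds shown here, three sharing one core have been tested in a functional assay on NCI-H3122 cells (Homo sapiens) for antiproliferative activity, read by MTT assay, with a stated time of 48 h; a higher number here means a weaker inhibitor, a lower number a stronger inhibitor. Compound 1 `CC(Oc1cccnc1Nc1cnn(C)c1)c1cccc(C(=O)NCc2ccc(F)cc2)c1` gives 43800 nM. Compound 2 `CC(Oc1cccnc1Nc1cnn(C)c1)c1cccc(C(=O)NCc2ccccc2S(=O)(=O)C(C)C)c1` reaches only the limit of the assay, > 100000 nM, so no number is available for it. Compound 3 `Cc1ccc(CNC(=O)c2cccc(C(C)Oc3cccnc3Nc3nccs3)c2)cc1` gives 15300 nM, which is the lowest of the two numbers available, with compound 1 as its nearest neighbour.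

For the measured compounds named here, the one measured step, an at least 2.2-fold higher number from compound 1 to compound 2 (0.35 log units; beyond the scatter), concerns the group on the saturated chain carbon bound to the amide-type nitrogen, and it ends at a limit, which is why it can only be read as a lower bound (the limit of > 100000 nM in this assay, at which 1 of the 3 values shown sits).

Compound 4 `Cc1ccc(CNC(=O)c2cccc(C(C)Oc3cccnc3Nc3nncs3)c2)cc1` differs from compound 3 in a different place: 1,3,4-thiadiazol-2-yl in place of 1,3-thiazol-2-yl on a nitrogen on an aromatic ring. Going by the values given here, no measured step touches this part of the molecule, so the measured step gives no guide to its size or direction. In the absence of any evidence on this ring, the expectation is that the step of a 1.0-fold lower number from compound 3 to compound 4 (0.01 log units; within the scatter) stays within the scatter of repeated measurement. Compound 4 is therefore estimated at 15000 nM in this assay, with a range from 5000 nM to 50000 nM.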

Compound 4, half-maximal inhibitory concentration: 20800 nM
Compound 4: the middle estimate sits 1.4-fold (0.14 log units) below what was measured; the range from low to high includes it.
By their numbers in this assay, from the lowest: compounds 3 and 4 (each within the scatter of the next); then compound 1. At a limit, above all of these: compound 2.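

In this assay, the exchange at this position gives a 1.4-fold higher number from compound 3 to compound 4 (0.13 log units; within the scatter), so replacing 1,3-thiazol-2-yl with 1,3,4-thiadiazol-2-yl on the amine nitrogen produces no change that can be told apart from ordinary repeat variation. For the compounds shown here, the earlier step concerned only the group on the saturated chain carbon at the other end of the molecule, whereas this is the first reading on the ring carried by the nitrogen, and it shows that one ring carbon can give way to a ring nitrogen, with the ring size and the absence of net charge unchanged, without a clear shift in the antiproliferative read-out. Nothing in the data shown speaks to why the two rings read alike.

Going by these compounds, it remains open whether a ring without sulfur, such as a phenyl ring, or a much smaller group, such as a single methyl, on this nitrogen would move the number beyond the scatter. Compound 1 and compound 3 differ in more than one place, so the share of the ring on the nitrogen in the gap between their values also remains unresolved.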